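A Smaller Halogen in Place of Trifluoromethyl

This account rests on a few compounds, and the source may have more. Where it says the series, first, only, none or still open, it means among the compounds named here.

Three compounds sharing one core were measured in a functional assay on RKE cells for antagonist activity at Vasoactive intestinal polypeptide receptor 1 (Rattus norvegicus), read by HTRF and cAMP accumulation, with stated times of 10 min and 30 min; on this read-out lower numbers stand for stronger inhibition and higher numbers for weaker inhibition. Compound 1 `CC(C)c1cc(C(C)(C)C)cc(-c2cccc(C(F)(F)F)c2)c1CO` returns only a limit in this assay, > 50000 nM, and not a number. Compound 2 `CC(C)c1cc(C(C)(C)C)cc(-c2ccccc2-c2ccccc2)c1CO` gives 3200 nM in this assay. Compound 3 `CC(C)c1cc(C(C)(C)C)cc(-c2cccc3ccccc23)c1CO` gives 180 nM in this assay. Compound 1 therefore sits at the limit of > 50000 nM in this assay, at which 1 of the 3 values shown sits, while compound 2 and compound 3 return measured numbers.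

Compound 4 `CC(C)c1cc(C(C)(C)C)cc(-c2cccc(Cl)c2)c1CO` has not yet been measured. It differs from compound 1 in one place: chloro in place of trifluoromethyl on an aromatic carbon. Going by the values given here, no measured pair differing in a single place is available, so the size of such a step cannot be read from the data, and nothing here gives a property of the change.

Since compound 1 itself returns only a limit, what is expected for compound 4 is a value near that same limit, with an estimated step from compound 1 to compound 4 of an at least 1.2-fold lower number from compound 1 to compound 4 (0.09 log units; that floor lies within the scatter), not beyond the usual scatter in either direction. Compound 4 is accordingly estimated at 40000 nM in this assay, with a range from 8000 nM to 200000 nM, and a substantial chance that only a limit is reported again.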

Compound 4, half-maximal inhibitory concentration: 100 nM
Beside the measured number, compound 4's estimate is 400-fold (2.60 log units) above it, outside the stated range (below it).
By their numbers in this assay, from the lowest: compounds 4 and 3 (each within the scatter of the next); then compound 2. At a limit, above all of these: compound 1.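

In this assay, replacing trifluoromethyl with chloro on an aromatic carbon meta to a large group gives an at least 500-fold lower number from compound 1 to compound 4 (2.69 log units; beyond the scatter). The earlier compounds shown here left open whether any group at this place would end the inhibition, and this result shows that the place itself does not: the outcome there depends strongly on which group is present, with one heavy atom of chlorine giving a measured number where the four heavy atoms of trifluoromethyl did not. The true size of the step remains unknown and the printed figure is only a floor, since compound 1 stands at a limit of the assay and not at a number: the limit of > 50000 nM in this assay, at which 1 of the 4 values shown sits.

The compounds shown give no measured property of either group, so they do not establish why chloro and trifluoromethyl part so widely. Going by these compounds, it also remains open whether fluoro, methyl, methoxy or nitrile at the same place would follow chloro or trifluoromethyl, and whether an amine or a carboxylic acid would be accepted there.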